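The source may hold more compounds than are shown below. What is called first, only, known or untested is meant among the compounds shown, and "the series" means these compounds.

Among the measured compounds shown here, in a functional assay on HCC827 cells (Homo sapiens) for inhibition, read by MTT assay, with a stated time of 48 h, tested at 10 uM (on this read-out higher numbers stand for more inhibition at the one concentration tested (going by the name of the read-out) and lower numbers for less inhibition), compound 1 `Cc1ccc(Nc2cc(NC(=O)Nc3c(Cl)cccc3Cl)ncn2)cc1F` gives 85.3%, the higher of the two numbers known here, while compound 2 `CCc1ccc(Nc2cc(NC(=O)Nc3cc(OC)cc(OC)c3)ncn2)cc1` gives 66.2%, a gap beyond the usual scatter. Compound 3 `COc1ccc(F)cc1Nc1cc(NC(=O)Nc2c(Cl)cccc2Cl)ncn1` has not been measured. It differs from compound 1 in one place: 5-fluoro-2-methoxyphenyl in place of 3-fluoro-4-methylphenyl on a nitrogen on an aromatic ring. For the measured compounds named here, no two measured compounds differ in a single place, so the size of this step has no direct precedent. The change is expected to lower inhibition in this assay by a modest amount, possibly no further than the scatter. Compound 3 is expected to give 74%, between 50% and 92%. That corresponds to an expected step of a number 11.3 percentage points lower from compound 1 to compound 3 (beyond the scatter).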

Compound 3, a percentage reported as inhibition, at one concentration (the size of the read-out at that concentration, not a potency): 78%
The estimate for compound 3 lay 4 percentage points below the measured number; the measured number falls inside the stated range.
By their numbers in this assay, from the lowest: compound 2; then compounds 3 and 1 (each within the scatter of the next).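

Going from 3-fluoro-4-methylphenyl to 5-fluoro-2-methoxyphenyl on a nitrogen on an aromatic ring gives a number 7.3 percentage points lower from compound 1 to compound 3 (within the scatter) in this assay. This first single-place comparison shows that this position accepts both groups without a difference that can be told from the scatter, including the one that adds a hydrogen-bond acceptor. No supporting evidence offers an explanation for this result.

On these data alone, whether a carboxylic acid or a morpholine at this place would keep inhibition remains open. So does the contribution of the other groups, as compound 2 differs from compound 1 in more than one place.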